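Solubility outlook for a fused bicyclic replacement on compound 2

The source may hold more compounds than are shown below. What is called first, only, known or untested is meant among the compounds shown, and "the series" means these compounds.

Three compounds share a core in which a urea links a substituted phenyl group to a five-membered ring bearing a heteroaromatic group on its amine nitrogen. Compound 1 `CNc1nccc(N2CC[C@H](NC(=O)Nc3ccc(Cl)c(C(F)(F)F)c3)C2)n1` gives 22200 nM in a physicochemical assay for solubility, measured as kinetic solubility; on this read-out lower numbers stand for lower solubility and higher numbers for higher solubility. Compound 2 `Nc1nccc(N2CC[C@H](NC(=O)Nc3ccc(Cl)c(C(F)(F)F)c3)C2)n1` gives 30300 nM in this assay, the second highest of the three numbers; compound 3 `CNc1nccc(N2CC[C@H](NC(=O)Nc3ccc(OC(F)(F)F)cc3)C2)n1` gives 70400 nM in this assay, a number beyond the scatter above that of compound 2. Going by the values given here, the one step between neighbours, a 1.4-fold higher number from compound 1 to compound 2 (0.14 log units; within the scatter), concerns hydrogen in place of methyl on a nitrogen on an aromatic ring.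

Compound 4 `O=C(Nc1ccc(Cl)c(C(F)(F)F)c1)N[C@H]1CCN(c2ccc3nncn3n2)C1` has not been measured. It differs from compound 2 in this way: a group of 9 heavy atoms (5 carbon, 4 nitrogen; one five-membered aromatic ring with 3 hetero atoms, one six-membered aromatic ring with 2 hetero atoms) in place of a group of 7 heavy atoms (4 carbon, 3 nitrogen; one six-membered aromatic ring with 2 hetero atoms), on an amine nitrogen in a ring. Among the compounds with values here, no measured step touches this part of the molecule, so the step from compound 1 to compound 2, itself within the scatter, offers no direct guide. Within the data shown here, with no comparable precedent, only a modest movement is expected, and the estimate leans toward a lower number, since the entering group replaces a hydrogen-bond donor with none while adding aromatic atoms.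

Compound 4 is expected to give about 15000 nM in this assay, within a range of 5000 nM to 45000 nM, an expected step of a 2.0-fold lower number from compound 2 to compound 4 (0.31 log units; beyond the scatter).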

Compound 4, solubility: 1000 nM
For compound 4 the middle estimate is 15-fold (1.18 log units) above the measured one; the whole stated range lies above it.
By their numbers in this assay, from the lowest: compound 4; then compounds 1 and 2 (each within the scatter of the next); then compound 3.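

In this assay, going by these compounds alone, the group on the amine nitrogen in the five-membered ring turns out to carry far more weight than the earlier compounds hinted. Within the data shown here, the only earlier step at this group, a small edit to its amine, gave a 1.4-fold higher number from compound 1 to compound 2 (0.14 log units; within the scatter) and so stayed within the scatter, whereas replacing the whole group with the fused pair of aromatic rings gives a 30-fold lower number from compound 2 to compound 4 (1.48 log units; beyond the scatter) and is large. The same replacement starting from the methylated amine gives a 22-fold lower number from compound 1 to compound 4 (1.35 log units; beyond the scatter) and is also large, so the fall does not depend on which of these two compounds serves as the starting point, although no measurement here bears on why the number falls.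

This swap removes the amine and its hydrogen-bond donor and adds a fused five-membered aromatic ring in a single move, and the compounds shown cannot tell these changes apart; an amine placed on the fused group, or a lone six-membered aromatic ring with 2 hetero atoms and no amine, would begin to do so. On these data alone, whether the fall also holds with the phenyl group of compound 3 on the urea remains open.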